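Ethyl to phenyl on the ring nitrogen of compound 2

The compounds below may be only part of what the source reports. "The series", "measured", "known", "first", "only" and "open" are said of these compounds alone.

For the measured compounds named here, compound 2 `CCN1C(=O)N(CC)C2C1NC(=S)N2/N=C/C=C/c1ccccc1OC` gives 250 nM in a functional assay on RD cells (Homo sapiens) for inhibition, read by MTT assay, with a stated time of 72 h (on this read-out higher numbers stand for weaker inhibition and lower numbers for stronger inhibition), the second highest of the three numbers known. Compound 1 `COc1ccccc1/C=C/C=N/N1C(=S)NC2C1N(C)C(=O)N2c1ccccc1` gives 20 nM, and compound 3 `CCN1C(=O)N(CC)C2C1NC(=S)N2/N=C/C=C/c1ccc(OC)cc1` gives 87000 nM. Going by the values given here, the only single-place step known is a 350-fold higher number from compound 2 to compound 3 (2.54 log units; beyond the scatter), which concerns the methoxyphenyl and does not bear on the change considered here. Compound 4 `CCN1C(=O)N(c2ccccc2)C2NC(=S)N(/N=C/C=C/c3ccccc3OC)C21` differs from compound 2 by phenyl in place of ethyl on an amide-type nitrogen in a ring. Among the compounds with values here, no measured step isolates this change: compound 1 also carries a phenyl on a ring nitrogen but differs from compound 2 in a second place as well, so its lower number can only be taken as a loose hint. On that basis a drop in this assay is expected for compound 4, moderate in size and far from certain, the step of a 4.2-fold lower number from compound 2 to compound 4 (0.62 log units; beyond the scatter) being the estimate. Compound 4 is therefore expected to give about 60 nM, within the range 15 nM to 250 nM.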

Compound 4, half-maximal inhibitory concentration: 45900 nM
Estimate against measurement, compound 4: 770-fold (2.88 log units) below, outside the stated range (above it).
By their numbers in this assay, from the lowest: compound 1; then compound 2; then compounds 4 and 3 (each within the scatter of the next).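

Phenyl in place of ethyl on this amide-type nitrogen in a ring is poorly tolerated in this assay when the ring atom's partner nitrogen carries ethyl, with a 180-fold higher number from compound 2 to compound 4 (2.26 log units; beyond the scatter) as the measured step. Phenyl at this place is therefore no guarantee of a low number: with phenyl held fixed, methyl in place of hydrogen on the saturated chain carbon gives a 2300-fold higher number from compound 1 to compound 4 (3.36 log units; beyond the scatter), so the low number of compound 1 depends on that small chain as well. Nothing at hand explains either step.

Still open, on these data alone, is how a propyl chain or a benzyl group would behave on the nitrogen that carries phenyl in compound 4. Also open, as far as these compounds go, is whether an amine or a carboxylic acid at the end of such a chain would be tolerated there.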